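Fluoro to Hydrogen on the Benzylamino Arm: Cytotoxicity Outlook

A few compounds are considered here, and "the series" means these few. Any claim that something is new, unique, unknown or untested is made for them only; others in the source may bear on it.

Compound 1 `O=c1nc(NCc2ccc(F)cc2)oc2c([N+](=O)[O-])cc(C(F)(F)F)cc12` was tested in an ADME assay on Vero cells (Chlorocebus sabaeus) for cytotoxicity, read by MTT assay, with a stated time of 48 h (on this read-out higher numbers stand for weaker inhibition and lower numbers for stronger inhibition), and gave only a limit, > 64 ug/mL, so no number stands for it. Compound 2 `O=c1cc(NCc2ccc3c(c2)OCCO3)sc2c([N+](=O)[O-])cc(C(F)(F)F)cc12` likewise sits at a limit in this assay, > 64 ug/mL. Compound 3 `O=c1cc(Nc2ccccc2)sc2c([N+](=O)[O-])cc(C(F)(F)F)cc12` also reaches only a limit, > 64 ug/mL. For the measured compounds named here, all three values therefore share (the limit of > 64 ug/mL in this assay, at which 3 of the 3 values shown sit), and no measured step between them can be sized. Compound 4 `O=c1nc(NCc2ccccc2)oc2c([N+](=O)[O-])cc(C(F)(F)F)cc12` differs from compound 1 by hydrogen in place of fluoro on an aromatic carbon. With every value shown a limit, no step beyond the scatter is expected in this assay, and the expected step that the limit leaves unreadable from compound 1 to compound 4 is none. Compound 4 is expected to give about 80 ug/mL in this assay, within a range from 40 ug/mL to 200 ug/mL, and most likely only a limit again.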

Compound 4, half-maximal inhibitory concentration: 25.4 ug/mL
For compound 4 the middle estimate is 3.1-fold (0.50 log units) above the measured one; measured number outside the range, below it.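

Hydrogen in place of fluoro on the benzylamino arm gives an at least 2.5-fold lower number from compound 1 to compound 4 (0.40 log units; beyond the scatter) in this assay, so a change at this place on the aromatic ring can register on this read-out. Compound 4 is the only compound shown with a number rather than a limit: the limit of > 64 ug/mL in this assay, at which 3 of the 4 values shown sit.

On these data alone, whether chloro, methyl or methoxy at the same place would give a number or a limit stays open. As far as these compounds go, the full size of this step also stays open, since compound 1 has only a limit, and the steps among the other compounds cannot be read.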